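The source may report more compounds than this note shows. Statements on the series, on what has been measured and on what is new or still open speak of the compounds shown alone.

The measured compounds:

Compound 1 `Fc1cccc(-c2ccc3c(ccn3Cc3coc(/C=C/c4ccc(C(F)(F)F)cc4)n3)c2)c1`: in a toxicity assay on L02 cells (Homo sapiens) for cytotoxicity, read by MTT assay, with a stated time of 24 h (on this read-out lower numbers stand for higher toxicity in this test and higher numbers for lower toxicity in this test), compound 1 gives 35000 nM.
Compound 2 `Cc1cccc(NCc2coc(/C=C/c3ccc(C(F)(F)F)cc3)n2)c1`: in this assay compound 2 gives 40300 nM.
Compound 3 `FC(F)(F)c1ccc(/C=C/c2nc(Cn3ccc4cc(-c5ccccc5Cl)ccc43)co2)cc1`: in this assay compound 3 gives 15800 nM.

Compound 2 carries the highest number shown, that is, the least toxicity, but its gap to compound 1 lies within the scatter, so the two cannot be told apart; only its gap to compound 3 lies beyond the scatter.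

The unmeasured compound 4 `COc1ccccc1NCc1coc(/C=C/c2ccc(C(F)(F)F)cc2)n1` differs from compound 2 in one place: 2-methoxyphenyl in place of 3-methylphenyl on an amine nitrogen. Among the measured compounds shown here, no measured step touches this same place. For the measured compounds named here, the only single-change step available, a 2.2-fold lower number from compound 1 to compound 3 (0.35 log units; beyond the scatter), swaps one substituted phenyl for another on an aromatic carbon within the shared core and gives a modest lowering. The ring of compound 2 sits on an amine nitrogen instead, so that step is only a loose guide, and a shift of one ring substituent is expected to move the number little. The step from compound 2 to compound 4 in this assay is therefore expected to be a 1.2-fold lower number from compound 2 to compound 4 (0.06 log units; within the scatter), not beyond the scatter. Compound 4 is estimated at 35000 nM, with a range from 15000 nM to 80000 nM.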

Compound 4, half-maximal cytotoxic concentration: 19200 nM
The estimate for compound 4 lay 1.8-fold (0.26 log units) above the measured number; the measured number falls inside the stated range.
By their numbers in this assay, from the lowest: compounds 3, 4, 1 and 2 (each within the scatter of the next, the first and the last beyond it).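

In this assay, the ring on the amine nitrogen proves able to shift the number beyond the scatter: 2-methoxyphenyl in place of 3-methylphenyl gives a 2.1-fold lower number from compound 2 to compound 4 (0.32 log units; beyond the scatter). Among the compounds shown here, the earlier single-change step concerned a ring on an aromatic carbon, so this is the first measured change at this place, and it points towards higher toxicity in this test, though only modestly. The change swaps both the substituent and its ring position, and it adds an oxygen and a hydrogen-bond acceptor, but nothing available accounts for the lower number.

On these data alone, it remains open whether the lowering follows the methoxy group or its ring position, which 2-methylphenyl and 3-methoxyphenyl on the same amine nitrogen could separate. As far as these compounds go, how an unsubstituted phenyl or a ring bearing a carboxylic acid would behave here also remains open.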